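Cyclohexyl in Place of an Aryl Cap in an HDAC6 Series

The source may hold more compounds than are shown below. What is called first, only, known or untested is meant among the compounds shown, and "the series" means these compounds.

In an assay on isolated protein for inhibition of protein deacetylase HDAC6 (Homo sapiens), read by fluorescence, with stated times of 5 min and 60 min (a higher number here means a weaker inhibitor, a lower number a stronger inhibitor), three compounds have been measured:
compound 1 `O=C(CCC1C(=O)N(c2ccc(Cl)cc2)C(=O)N1Cc1ccc(Br)cc1)NCc1ccc(C(=O)NO)cc1` gives 16.5 nM;
compound 2 `Cc1ccc(CN2C(=O)N(c3ccc(Cl)cc3)C(=O)C2CCC(=O)NCc2ccc(C(=O)NO)cc2)cc1` gives 18.9 nM;
compound 3 `O=C(CCC1C(=O)N(c2ccc(Cl)cc2)C(=O)N1Cc1ccccc1)NCc1ccc(C(=O)NO)cc1` gives 12.7 nM.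

Compound 2 carries the highest of the three numbers, yet the steps of a 1.1-fold higher number from compound 1 to compound 2 (0.06 log units; within the scatter) and a 1.5-fold lower number from compound 2 to compound 3 (0.17 log units; within the scatter) both lie within the scatter, as does a 1.3-fold lower number from compound 1 to compound 3 (0.11 log units; within the scatter).

Compound 4 `Cc1ccc(CN2C(=O)N(C3CCCCC3)C(=O)C2CCC(=O)NCc2ccc(C(=O)NO)cc2)cc1` differs from compound 2 by cyclohexyl in place of 4-chlorophenyl on an amide-type nitrogen in a ring. Within the data shown here, no measured step touches this position: all three vary the substituent on the benzyl ring and each stays within the scatter, so they give no guidance on size or direction. Compound 4 is therefore expected to remain near compound 2, with a somewhat higher number allowed in this assay, an expected step of a 1.6-fold higher number from compound 2 to compound 4 (0.20 log units; within the scatter). Compound 4 is estimated at 30 nM, within 10 nM to 100 nM.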

Compound 4, half-maximal inhibitory concentration: 17 nM
Beside the measured number, compound 4's estimate is 1.8-fold (0.25 log units) above it; the measured number falls inside the stated range.
By their numbers in this assay, from the lowest: compounds 3, 1, 4 and 2 (each within the scatter of the next).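

In this assay, among these compounds, this is the first change at the amide-type nitrogen in a ring, and it gives a 1.1-fold lower number from compound 2 to compound 4 (0.05 log units; within the scatter). Cyclohexyl thus stands in for 4-chlorophenyl without a step beyond the scatter, so neither the aromatic ring nor the chlorine is required at this position for a number in this range. Nothing available explains why this is so.

As far as these compounds go, it remains open whether a tert-butyl group or a piperidine ring at this nitrogen would also stay within the scatter. Also open, from the compounds shown here alone, is whether cyclohexyl behaves the same way alongside the benzyl groups of compound 1 and compound 3.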